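This account rests on a few compounds, and the source may have more. Where it says the series, first, only, none or still open, it means among the compounds named here.

In a functional assay on SW-620 cells (Homo sapiens) for inhibition, read by MTT assay, with a stated time of 72 h (a higher number here means a weaker inhibitor, a lower number a stronger inhibitor), compound 2 `COc1cc(Oc2cccc(Nc3ccccc3)c2)cc(OC)c1CNCc1ccccc1` gives 7490 nM, and compound 1 `COc1ccc(CNCc2c(OC)cc(Oc3cccc(Nc4ccccc4)c3)cc2OC)cc1` gives 6970 nM. For the measured compounds named here, these are the only two measured values, and they lie within the scatter of each other. The next compound, compound 3 `COc1cc(Oc2cccc(Nc3ccccc3)c2)cc(OC)c1CNCc1ccc(C)cc1`, departs from compound 2 by one change: methyl in place of hydrogen on an aromatic carbon. Going by the values given here, only one measured step bears on it. At that same carbon, compound 1 carries a methoxy where compound 2 has hydrogen, and this exchange amounts to a 1.1-fold higher number from compound 1 to compound 2 (0.03 log units; within the scatter). One step offers thin evidence, but it gives no reason to expect a shift from a single small group here. The expected change is a 1.1-fold lower number from compound 2 to compound 3 (0.03 log units; within the scatter), which would be no step beyond the scatter. The estimate for compound 3 is 7000 nM, with an expected range of 3500 nM to 14000 nM.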

Compound 3, half-maximal inhibitory concentration: 11800 nM
Compound 3: the middle estimate sits 1.7-fold (0.23 log units) below what was measured, within the range that was stated.
By their numbers in this assay, from the lowest: compounds 1, 2 and 3 (each within the scatter of the next).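

In this assay, the change from benzyl to 4-methylbenzyl is a 1.6-fold higher number from compound 2 to compound 3 (0.20 log units; within the scatter), so a methyl on this aromatic carbon, para to a large group, cannot be told apart from hydrogen. The exchange between the two larger groups at this carbon is a 1.7-fold higher number from compound 1 to compound 3 (0.23 log units; within the scatter), which means that this position has now carried hydrogen, methoxy and methyl with no step beyond the scatter among them. No accompanying measurement offers an explanation for these numbers.

As far as these compounds go, whether a carboxylic acid, an amine or a trifluoromethyl at this same carbon would give a step beyond the scatter remains open. So does whether a change elsewhere on the shared core would move the number further than these three groups have.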